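Acyl variation on the trimethoxyphenyl benzylamine series

The source may hold more compounds than are shown below. What is called first, only, known or untested is meant among the compounds shown, and "the series" means these compounds.

Measured so far:
compound 1 `COc1ccc(CNc2cc(OC)c(OC)c(OC)c2)cc1Br` — 48100 nM
compound 2 `C#CC(=O)N(Cc1ccc(OC)c(O)c1)c1cc(OC)c(OC)c(OC)c1` — 310 nM
compound 3 `C/C=C/C(=O)N(Cc1cccc(O)c1)c1cc(OC)c(OC)c(OC)c1` — 6700 nM

In a functional assay on HCT-116 cells (Homo sapiens) for inhibition, read by MTT assay, with a stated time of 48 h (on this read-out lower numbers stand for stronger inhibition and higher numbers for weaker inhibition), compound 2 gives the lowest number of the three, and its separation from both neighbours is beyond the scatter: compound 3 sits far above it, and compound 1, which carries no acyl group at all, sits furthest away. Among the compounds with values here, the three compounds differ in more than one place, so no single step between them can be isolated; they show only that the acylated compounds 2 and 3 give lower numbers than the unacylated compound 1, with compound 2 well below compound 3.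

Compound 4 `COc1ccc(CN(C(=O)CCCCCl)c2cc(OC)c(OC)c(OC)c2)cc1O` is the next compound for this assay. It is derived from compound 2 by one change:

4-chlorobutyl in place of ethynyl on a carbonyl carbon

Within the data shown here, the ethynylcarbonyl of compound 2 is the only acyl group here paired with a low number, and no measured compound carries a saturated chain of this kind on the carbonyl carbon. Against that background, compound 4 is expected to give a higher number than compound 2, with a step of a 16-fold higher number from compound 2 to compound 4 (1.21 log units; beyond the scatter) that lies beyond the scatter. The estimate for compound 4 in this assay is 5000 nM, within a range from 1000 nM to 25000 nM.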

Compound 4, half-maximal inhibitory concentration: 220 nM
Compound 4: middle estimate off by 23-fold (1.36 log units), on the high side, outside the stated range (below it).
By their numbers in this assay, from the lowest: compounds 4 and 2 (each within the scatter of the next); then compound 3; then compound 1.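

In this assay, 4-chlorobutyl in place of ethynyl on a carbonyl carbon gives a 1.4-fold lower number from compound 2 to compound 4 (0.15 log units; within the scatter), so this pair does not separate on this read-out. The low number of compound 2 therefore does not depend on the ethynylcarbonyl: in this pair, the carbonyl carbon carries either ethynyl or a saturated chain ending in chlorine with no difference beyond the scatter. No supporting data bear on why the two acyl groups read alike.

Going by these compounds, the role of the chlorine remains open: a plain butyl chain, a longer chain with chlorine or an amine in place of the chlorine would each test a separate part of this group. On these data alone, it also remains open whether this match between ethynyl and 4-chlorobutyl holds on the core of compound 3, which differs from compound 2 and compound 4 in more than one place.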